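This account rests on a few compounds, and the source may have more. Where it says the series, first, only, none or still open, it means among the compounds named here.

Measured so far:
compound 1 `O=C(Nc1cccc(-c2oc3cc(-c4ccc(F)cc4)ccc3c(=O)c2O)c1)c1ccc(C(F)(F)F)cc1`: 33000 nM
compound 2 `O=C(Nc1cccc(-c2oc3cc(-c4ccc(F)cc4)ccc3c(=O)c2O)c1)c1cccc(F)c1`: 15800 nM

In a functional assay on GTL 16 cells for antiproliferative activity against GTL 16 cell line (Homo sapiens), read by CCK-8 assay, with a stated time of 72 h (a lower number here means a stronger inhibitor, a higher number a weaker inhibitor), compound 2 gives 15800 nM, the lowest of the two numbers shown. Compound 1 gives 33000 nM in this assay, and the step of a 2.1-fold lower number from compound 1 to compound 2 (0.32 log units; beyond the scatter) lies beyond the scatter. Compound 3 `O=C(Nc1cccc(-c2oc3cc(-c4ccc(F)cc4)ccc3c(=O)c2O)c1)c1ccc(Cl)nc1` differs from compound 2 by 6-chloropyridin-3-yl in place of 3-fluorophenyl on a carbonyl carbon. Among the compounds with values here, the one measured step, a 2.1-fold lower number from compound 1 to compound 2 (0.32 log units; beyond the scatter), also swapped the group on the carbonyl carbon, yet to a different group, so it gives no direct guide to this change, and no other step bears on it. A step within the scatter is therefore expected, a 1.1-fold lower number from compound 2 to compound 3 (0.02 log units; within the scatter). Compound 3 is estimated at 15000 nM, with a range from 6000 nM to 40000 nM.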

Compound 3, half-maximal inhibitory concentration: 7520 nM
Beside the measured number, compound 3's estimate is 2.0-fold (0.30 log units) above it; the measured number falls inside the stated range.
By their numbers in this assay, from the lowest: compound 3; then compound 2; then compound 1.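

In this assay, the group on the carbonyl carbon keeps moving the number: 6-chloropyridin-3-yl, the only ring here with a hetero atom, gives a 2.1-fold lower number from compound 2 to compound 3 (0.32 log units; beyond the scatter) and, against 4-(trifluoromethyl)phenyl, a 4.4-fold lower number from compound 1 to compound 3 (0.64 log units; beyond the scatter). Compound 3 therefore has the lowest number of the three, with each step beyond the scatter. Nothing shown gives a reason for this result.

From the compounds shown here alone, the change brings in the ring nitrogen and the chlorine together, and their separate shares remain open. A plain pyridin-3-yl group, or a 6-aminopyridin-3-yl group, would test them.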